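The source may report more compounds than this note shows. Statements on the series, on what has been measured and on what is new or still open speak of the compounds shown alone.

Measured compounds in a functional assay on HepG2 cells (Homo sapiens) for cytotoxicity, read by MTT assay, with a stated time of 72 h; a higher number here means that more compound is needed for the effect, a lower number that less compound is needed:
Compound 1 `CCS[C@@H]1[C@H](SCC)[C@@H](Cn2cc(-c3ccccc3C(F)(F)F)nn2)O[C@H]1n1ccc(=O)[nH]c1=O` gives 30300 nM.
Compound 2 `CCS[C@@H]1[C@H](SCC)[C@@H](Cn2cc(COC(C)=O)nn2)O[C@H]1n1ccc(=O)[nH]c1=O` gives >= 100000 nM, which is a limit of the assay and not a number.

Compound 2 thus stands at the limit of >= 100000 nM in this assay, at which 1 of the 2 values shown sits; of the two compounds measured it is the one with only a range and no definite value. The step of an at least 3.3-fold higher number from compound 1 to compound 2 (0.51 log units; beyond the scatter) shows that exchanging the 2-(trifluoromethyl)phenyl of compound 1 for acetoxymethyl pushed the number beyond what the assay reports. Compound 3 `CCS[C@@H]1[C@H](SCC)[C@@H](Cn2cc(-c3cccs3)nn2)O[C@H]1n1ccc(=O)[nH]c1=O` is the next compound to be measured, and it differs from compound 2 as follows: thiophen-2-yl in place of acetoxymethyl on an aromatic carbon. Among the measured compounds shown here, only that one measured step bears on this change, and it ran in the opposite direction, from an aromatic substituent to acetoxymethyl; compound 3 places an aromatic ring back on the same carbon, though thiophen-2-yl is not the substituent carried by compound 1. Compound 3 is therefore expected to give a lower number than the limit of compound 2, a step of an at least 2.5-fold lower number from compound 2 to compound 3 (0.39 log units; beyond the scatter) in the lower direction. The estimate for compound 3 is 40000 nM, with a range from 15000 nM to 100000 nM, and a real chance that only a limit is reported again.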

Compound 3, half-maximal effective concentration: 91800 nM
Compound 3: middle estimate off by 2.3-fold (0.36 log units), on the low side; the range from low to high includes it.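

In this assay, thiophen-2-yl on this aromatic carbon of the five-membered aromatic ring with 3 nitrogen gives a definite value, yet the change from acetoxymethyl cannot be told apart from no change, with the step reading an at least 1.0-fold lower number from compound 2 to compound 3 (0.03 log units; that floor lies within the scatter). The comparison between the two aromatic substituents can be read, with a 3.0-fold higher number from compound 1 to compound 3 (0.48 log units; beyond the scatter), so the identity of the aromatic group matters at this carbon, and an aromatic ring here does not by itself bring the number down to that of compound 1. The value of compound 2 remains a limit of the assay and not a number, which is what leaves the first step open-ended: the limit of >= 100000 nM in this assay, at which 1 of the 3 values shown sits.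

On these data alone, what the lower number of compound 1 depends on stays open, since a plain phenyl, or a phenyl carrying a methyl in place of the trifluoromethyl, would be needed to separate the ring from its substituent. As far as these compounds go, it also remains open how an amine or a carboxylic acid on this same carbon would move the number in this assay.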